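The source may hold more compounds than are shown below. What is called first, only, known or untested is meant among the compounds shown, and "the series" means these compounds.

Compound 1 `Fc1cccc(-c2nc(Nc3cccc(Cl)c3)c3cc(F)ccc3n2)c1` belongs to a small series tested in a functional assay on U2OS cells (Homo sapiens) for cytotoxicity, read by MTT assay, with a stated time of 48 h; a lower number here means a stronger inhibitor, a higher number a weaker inhibitor. In this assay compound 1 gives > 50000 nM, which is a limit of the assay and not a measured number, as recorded in the limit of > 50000 nM in this assay, at which 1 of the 2 values shown sits. Within the data shown here, compound 2 `Oc1cccc(Nc2nc(-c3cccc(F)c3)nc3ccc(F)cc23)c1` is the one measured neighbour, and in this assay compound 2 gives 33300 nM. The step of an at least 1.5-fold lower number from compound 1 to compound 2 (0.17 log units; that floor lies within the scatter) comes from a hydroxy in place of chloro on an aromatic carbon.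

The unmeasured compound 3 `Cc1ccccc1Nc1nc(-c2cccc(F)c2)nc2ccc(F)cc12` differs from compound 1 in one place: 2-methylphenyl in place of 3-chlorophenyl on a nitrogen on an aromatic ring. Among the measured compounds shown here, no measured step involves a 2-methylphenyl group on a nitrogen on an aromatic ring, and the one step that exists, an at least 1.5-fold lower number from compound 1 to compound 2 (0.17 log units; that floor lies within the scatter), concerns a different change and has a floor that lies within the scatter. For compound 3 no change beyond the scatter is therefore expected, and the step from compound 1 is estimated as a number no higher from compound 1 to compound 3 (the limit leaves the size open). Compound 3 is expected to give 50000 nM in this assay, with a range from 20000 nM to 150000 nM, and it may well again reach only the limit of the assay.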

Compound 3, half-maximal inhibitory concentration: > 50000 nM
Compound 3: no number, only a limit (the forecaster's own chance of this, stated with the estimate: 55%); the middle value sits exactly at the limit.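

In this assay compound 3 gives > 50000 nM, which is a limit of the assay and not a number. The step between compound 1 and compound 3 cannot be read, because both compounds stop at the same limit: the limit of > 50000 nM in this assay, at which 2 of the 3 values shown sit. Among these compounds, the one readable new step is an at least 1.5-fold higher number from compound 2 to compound 3 (0.17 log units; that floor lies within the scatter), so the nitrogen on an aromatic ring has now carried three different groups without any step printed as beyond the scatter.

The compounds shown leave open whether the hydroxy group of compound 2 truly sets it apart from compound 1 and compound 3, as each of its steps has only a floor that lies within the scatter. They also leave open whether a phenyl ring at this nitrogen carrying an amine or a carboxylic acid, or a longer alkyl chain in place of the ring, would give a value clearly lower than that of compound 2.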